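The source may report more compounds than this note shows. Statements on the series, on what has been measured and on what is new or still open speak of the compounds shown alone.

Measured so far in a functional assay on HeLa cells (Homo sapiens) for cytotoxicity, read by MTT assay, with a stated time of 48 h (on this read-out higher numbers stand for weaker inhibition and lower numbers for stronger inhibition), each value being a limit of the assay and not a number:

Compound 1 `COc1ccc(/C=C/C(=O)/C=C/c2cc3ccccc3nc2Cl)cc1`: > 10000 nM
Compound 2 `COc1ccc(/C=C/C(=O)/C=C/c2cc3ccccc3nc2Oc2ccccc2)cc1`: > 10000 nM
Compound 3 `COc1ccc(/C=C/C(=O)/C=C/c2cc3ccccc3nc2Oc2ccccc2)cc1OC`: > 10000 nM

The starting point here, compound 2, has no exact value on these numbers. Compound 2 is recorded at > 10000 nM, which is a limit. The other two compounds give no firmer footing, and the whole set rests on (the limit of > 10000 nM in this assay, at which 3 of the 3 values shown sit).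

Compound 4 `COc1ccc(/C=C/C(=O)/C=C/c2cc3ccccc3nc2Oc2ccc(Br)cc2)cc1` is not yet measured. It differs from compound 2 by bromo in place of hydrogen on an aromatic carbon. In words, this is bromo in place of hydrogen on an aromatic carbon, turning phenoxy into 4-bromophenoxy, para to a large group.

Two measured changes bear on this one. Phenoxy in place of chloro gives a step that the two limits leave unreadable from compound 1 to compound 2. Methoxy in place of hydrogen, also on an aromatic carbon and the closer parallel, gives a step that the two limits leave unreadable from compound 2 to compound 3. Neither has a size that can be carried over, so the data point to no direction for the new change. The likeliest result is that compound 4 is again reported only as a limit in this assay.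

The expected change is a step that the limit leaves unreadable from compound 2 to compound 4. Compound 4 is estimated at 15000 nM, with an expected range from 5000 nM to 40000 nM.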

Compound 4, half-maximal inhibitory concentration: > 10000 nM
Compound 4: no number, only a limit; the forecaster's own chance of this, stated with the estimate: 80%; the middle value does not contradict the limit.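

In this assay compound 4 gives > 10000 nM, which is a limit and not a number. The steps to compound 4 from compound 2 and from compound 1 therefore cannot be read: the limit of > 10000 nM in this assay, at which 4 of the 4 values shown sit.

The compounds shown leave open how strongly any of them truly acts on these cells, and whether bromo in place of hydrogen changes anything at all.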